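A few compounds are considered here, and "the series" means these few. Any claim that something is new, unique, unknown or untested is made for them only; others in the source may bear on it.

In a functional assay on RAW264.7 cells (Mus musculus) for inhibition, read by Griess assay, with stated times of 1 h and 24 h (a lower number here means a stronger inhibitor, a higher number a weaker inhibitor), compound 1 (`COc1ccc(C(O)C2OC(=O)c3c(OC)cc(OC)cc32)cc1`) reads > 10000 nM, which is a limit of the assay and not a number. Among the measured compounds shown here, compound 2 (`CCCOc1ccc(C(O)C2OC(=O)c3c(OC)cc(OC)cc32)cc1`) gives 9260 nM in this assay and is so far the only compound with a true number. The unmeasured compound 3 (`COCCOc1ccc(C(O)C2OC(=O)c3c(OC)cc(OC)cc32)cc1`) differs from compound 2 by methoxy in place of methyl on a saturated chain carbon, two bonds along the chain from an oxygen on an aromatic ring, or propoxy to 2-methoxyethoxy. For the measured compounds named here, one measured step bears on this change: an at least 1.0-fold lower number from compound 1 to compound 2 (0.03 log units; that floor lies within the scatter). Its floor lies within the scatter, and the limit of > 10000 nM in this assay, at which 1 of the 2 values shown sits, leaves its true size open. It therefore gives no firm guide to size or direction. From the compounds shown here alone, with only an at least 1.0-fold lower number from compound 1 to compound 2 (0.03 log units; that floor lies within the scatter) to go on, no step beyond the scatter is expected in this assay, and either direction remains open. The expected step is a 1.1-fold higher number from compound 2 to compound 3 (0.03 log units; within the scatter). For compound 3 the estimated value is 10000 nM, with an expected range of 4500 nM to 22000 nM.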

Compound 3, half-maximal inhibitory concentration: > 10000 nM
Compound 3 gave a limit, no number; the forecaster's own chance of this, stated with the estimate: 50%; the middle value sits exactly at the limit.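

In this assay compound 3 reads > 10000 nM, which is a limit of the assay and not a number. At this position, on a saturated chain carbon, two bonds along the chain from an oxygen on an aromatic ring, methoxy in place of methyl gives an at least 1.0-fold higher number from compound 2 to compound 3 (0.03 log units; that floor lies within the scatter), so the change from propoxy to 2-methoxyethoxy, which brings in one hydrogen-bond acceptor, does not yield a second true number in this assay. The step between compound 1 and compound 3 cannot be read, and the true size of the step to compound 3 stays open because of where the values sit: the limit of > 10000 nM in this assay, at which 2 of the 3 values shown sit.

Among the compounds shown here, compound 2, at 9260 nM, therefore remains the only true number, and how far compound 3 lies from it is unresolved. From the compounds shown here alone, whether a longer chain such as butoxy, or a chain ending in an amine or a carboxylic acid, would give a value clearly beyond the scatter from compound 2 stays open.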